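A ring swap among compounds held at a limit

A few compounds are considered here, and "the series" means these few. Any claim that something is new, unique, unknown or untested is made for them only; others in the source may bear on it.

Measured so far in a functional assay on ECV-304 cells (Homo sapiens) for cytotoxicity; a higher number here means a weaker inhibitor, a lower number a stronger inhibitor:
- Compound 1 `O=C1/C(=C/c2ccccc2F)SC(=S)N1NS(=O)(=O)c1ccccc1` gives > 50000 nM, a limit and not a number
- Compound 2 `O=C1/C(=C/c2ccc([N+](=O)[O-])cc2)SC(=S)N1NS(=O)(=O)c1ccccc1` gives > 50000 nM, a limit and not a number
- Compound 3 `O=C1/C(=C/c2ccc(F)c(F)c2F)SC(=S)N1NS(=O)(=O)c1ccccc1` gives > 50000 nM, a limit and not a number

Compound 3 has no exact value, only its limit of > 50000 nM in this assay. It shares that position with the other two compounds, as the limit of > 50000 nM in this assay, at which 3 of the 3 values shown sit, shows.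

Compound 4 `Cc1ccc(/C=C2\SC(=S)N(NS(=O)(=O)c3ccccc3)C2=O)cc1C` carries 3,4-dimethylphenyl in place of 2,3,4-trifluorophenyl on a double-bonded chain carbon bound to a double-bonded ring carbon.

Two measured changes at the same place bear on this: a step that the two limits leave unreadable from compound 1 to compound 3 and a step that the two limits leave unreadable from compound 2 to compound 3. Neither has a size that can be read, so they offer no number to carry over. Still, compound 1, compound 2 and compound 3 all failed to give a number, so no step beyond the scatter and no direction is expected in this assay. The expected size is an estimate, a step that the limit leaves unreadable from compound 3 to compound 4, and a further limit is the likeliest report.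

Compound 4 is estimated at 60000 nM, with an expected range from 30000 nM to 120000 nM.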

Compound 4, half-maximal inhibitory concentration: > 50000 nM
Compound 4 was reported as a limit; the forecaster's own chance of this, stated with the estimate: 85%; the middle value does not contradict the limit.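

Compound 4 sits at the same limit as compound 1, compound 2 and compound 3, so no step from any of them to compound 4 can be read: the limit of > 50000 nM in this assay, at which 4 of the 4 values shown sit.

Going by these compounds, whether these four compounds differ at all in this assay, and by how much, stays open.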